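The compounds below may be only part of what the source reports. "The series", "measured", "known", "first", "only" and "open" are said of these compounds alone.

Compound 1 `CC(=O)NNC(=O)c1csc2ncc(-c3ccc(C)cc3)n12`, compound 2 `CCC(=O)NNC(=O)c1csc2ncc(-c3ccc(C)cc3)n12` and compound 3 `CCC(=O)NNC(=O)c1csc2ncc(-c3ccc(Br)cc3)n12` have been measured; compound 4 `CCCC(=O)NNC(=O)c1csc2ncc(-c3ccc(Br)cc3)n12` has not.

In a functional assay on HeLa cells (Homo sapiens) for antiproliferative activity, read by MTT assay, with a stated time of 72 h (a higher number here means a weaker inhibitor, a lower number a stronger inhibitor), compound 1 gives 74200 nM. Compound 2 differs from compound 1 by methyl in place of hydrogen on a saturated chain carbon bound to a carbonyl carbon, and in this assay compound 2 gives 13000 nM, which is a 5.7-fold lower number from compound 1 to compound 2 (0.76 log units; beyond the scatter). Compound 3 has bromo in place of methyl on an aromatic carbon, and in this assay compound 3 gives 23100 nM, which is a 1.8-fold higher number from compound 2 to compound 3 (0.25 log units; within the scatter). How the core of compound 1 and the core of compound 3 differ is not broken down here.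

Compound 4 differs from compound 3 by methyl in place of hydrogen on a saturated chain carbon, two bonds along the chain from a carbonyl carbon. This is the same kind of change as that from compound 1 to compound 2, but not the same: there the new methyl sits on a saturated chain carbon bound to a carbonyl carbon, here on a saturated chain carbon two bonds along the chain from a carbonyl carbon, so the chain grows from ethyl to propyl. Among the compounds with values here, the only precedent is a 5.7-fold lower number from compound 1 to compound 2 (0.76 log units; beyond the scatter). A methyl cut one bond further out need not repeat that, so the step to compound 4 is expected to be smaller, a 1.9-fold lower number from compound 3 to compound 4 (0.28 log units; within the scatter). Compound 4 is therefore estimated to give about 12000 nM in this assay, plausibly between 4000 nM and 35000 nM.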

Compound 4, half-maximal inhibitory concentration: 31900 nM
Compound 4: middle estimate off by 2.7-fold (0.42 log units), on the low side, within the range that was stated.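

In this assay, the methyl that turns ethyl into propyl gives a 1.4-fold higher number from compound 3 to compound 4 (0.14 log units; within the scatter), so this longer chain brings no clear change on this core. The drop in the number seen on the core of compound 1 did not carry over to the core of compound 3: the same change on two cores in this assay, a 5.7-fold lower number (0.76 log units; beyond the scatter) from compound 1 to compound 2 and a 1.4-fold higher number (0.14 log units; within the scatter) from compound 3 to compound 4, 7.9-fold (0.90 log units) apart, beyond the scatter of two such steps. This shows that the earlier step cannot serve as a rule for this series, but it does not show what lies behind the gap: the two steps differ both in the core and in where the methyl sits, one bond further out here, and one pair on each side cannot separate these two differences.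

Still open, on these data alone, is whether propyl would behave the same way with methyl in place of bromo on the aromatic ring, which would test the core and the position apart. Also open, as far as these compounds go, is what a longer chain such as butyl, or an amine at the end of the chain, would do to the number.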